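The compounds below may be only part of what the source reports. "The series", "measured", "known", "first", "only" and "open" are said of these compounds alone.

Compound 2 `COc1cccc(OC)c1C1CCCC(=O)N1Cc1cccc(-c2ccccn2)c1` holds the lowest number of the two measured in a functional assay on CHO cells for antagonist activity at Orexin receptor type 2 (Homo sapiens), read by FLIPR and calcium flux (on this read-out lower numbers stand for stronger inhibition and higher numbers for weaker inhibition), giving 8 nM. Among the compounds with values here, compound 1 `COc1cccc(OC)c1C1CCCC(=O)N1Cc1ccccc1` gives 416 nM in this assay, and the only recorded step is a 52-fold lower number from compound 1 to compound 2 (1.72 log units; beyond the scatter). Compound 3 `COc1cccc(OC)c1C1CCCC(=O)N1Cc1cccc(-c2ncccn2)c1` differs from compound 2 by pyrimidin-2-yl in place of pyridin-2-yl on an aromatic carbon. Within the data shown here, no measured step bears directly on this exchange of one six-membered aromatic ring for another at the same place, so the large step between compound 1 and compound 2 offers little guidance. Compound 3 is therefore expected to show a 1.5-fold higher number from compound 2 to compound 3 (0.18 log units; within the scatter), within the scatter. Compound 3 is estimated at 12 nM, between 4 nM and 40 nM.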

Compound 3, half-maximal inhibitory concentration: 28 nM
For compound 3 the middle estimate is 2.3-fold (0.37 log units) below the measured one, and the stated range covers the measured number.
By their numbers in this assay, from the lowest: compound 2; then compound 3; then compound 1.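

At this aromatic carbon, meta to a large group, the choice of ring matters: with a 3.5-fold higher number from compound 2 to compound 3 (0.54 log units; beyond the scatter) in this assay, pyrimidin-2-yl does less well than pyridin-2-yl. Even so, a 15-fold lower number from compound 1 to compound 3 (1.17 log units; beyond the scatter) shows that most of the gain over hydrogen remains, so that gain is not confined to pyridin-2-yl. Nothing available here explains the difference between the two rings. Going by these compounds, how a phenyl ring, pyridin-3-yl or a morpholine would compare at this carbon remains open. So does whether pyrimidin-2-yl would rank the same way on a different core.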